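Ester to Amide at the Chain End of Compound 1

The compounds below may be only part of what the source reports. "The series", "measured", "known", "first", "only" and "open" are said of these compounds alone.

Measured so far:
compound 1, `C=CCOC(=O)/C=C(C)/C=C/CC(C)CCCC(C)C`, 6.73;
compound 2, `C=CCOC(=O)/C=C(C)/C=C/CC(C)CCCC(C)(C)OC`, 5.53;
compound 3, `CCNC(=O)OC(C)(C)CCCC(C)C/C=C/C(C)=C/C(=O)OC(C)C`, 6.06.

In a physicochemical assay for lipophilicity (a higher number here means a more lipophilic compound, a lower number a more polar compound), compound 1 stands highest of the three, with compound 3 nearest and compound 2 furthest. For the measured compounds named here, the one single-site step known, a number 1.20 log units lower from compound 1 to compound 2 (beyond the scatter), concerns a change elsewhere on the chain and does not touch the ester end. Compound 4, `CCN(CC)C(=O)/C=C(C)/C=C/CC(C)CCCC(C)C`, differs from compound 1 by diethylamino in place of allyloxy on a carbonyl carbon. No measured pair covers this kind of exchange, so the expectation rests on the change itself rather than on a shown step. An ester giving way to a tertiary amide is expected to lower the number in this assay by a moderate amount, beyond the scatter: a number 0.83 log units lower from compound 1 to compound 4 (beyond the scatter). Compound 4 is therefore estimated at 5.9, within 5.3 to 6.5.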

Compound 4, partition coefficient: 6.02
Beside the measured number, compound 4's estimate is 0.12 log units below it; measured number inside the range.
By their numbers in this assay, from the lowest: compound 2; then compounds 4 and 3 (each within the scatter of the next); then compound 1.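

In this assay, the carbonyl end of the chain now has a measured step of its own: a number 0.71 log units lower from compound 1 to compound 4 (beyond the scatter) when diethylamino takes the place of allyloxy on a carbonyl carbon. This position therefore responds to the change from allyloxycarbonyl to diethylcarbamoyl, with a modest step beyond the scatter. Nothing measured here accounts for the size of this step.

On these data alone, whether dimethylamino or piperidine on the same carbonyl carbon would give a similar step remains open. As far as these compounds go, a carboxylic acid at this place also remains open.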